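The compounds below may be only part of what the source reports. "The series", "measured", "known", "first", "only" and "open" are said of these compounds alone.

Measured in an in vitro ADME assay on microsomes from liver (Homo sapiens) for metabolic stability; on this read-out higher numbers stand for fast clearance and lower numbers for slow clearance:
Compound 1 `O=C(C=C1CCN(C(=O)c2ccccc2F)CC1)N[C@@H]1CCN(Cc2ccc3cc(F)ccc3c2)C1`: 590 mL/min/kg
Compound 2 `COc1ccc(C(=O)N2CCC(=CC(=O)N[C@@H]3CCN(Cc4ccc5cc(F)ccc5c4)C3)CC2)cc1OC`: 246 mL/min/kg

Of these two, compound 2 has the lower number, and the gap to compound 1 lies beyond the scatter. The next compound to be measured is compound 3 `O=C(C=C1CCN(C(=O)c2cccc(F)c2)CC1)N[C@@H]1CCN(Cc2ccc3cc(F)ccc3c2)C1`. Its difference from compound 2 is 3-fluorophenyl in place of 3,4-dimethoxyphenyl on a carbonyl carbon.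

Among the compounds with values here, only one measured step bears on this place: a 2.4-fold lower number from compound 1 to compound 2 (0.38 log units; beyond the scatter), which is modest. From the compounds shown here alone, compound 3 again carries a fluorophenyl group, as compound 1 does, but not the same one, so 3-fluorophenyl itself remains untested. A step of similar size in the opposite direction, towards faster clearance, is therefore expected from that step of compound 1 to compound 2. The expected change is a 2.0-fold higher number from compound 2 to compound 3 (0.29 log units; within the scatter). For compound 3 the estimated value is 480 mL/min/kg, with an expected range of 220 mL/min/kg to 950 mL/min/kg.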

Compound 3, clearance: 459 mL/min/kg
Beside the measured number, compound 3's estimate is 1.0-fold (0.02 log units) above it; low and high end bracket the measured number.
By their numbers in this assay, from the lowest: compounds 2, 3 and 1 (each within the scatter of the next, the first and the last beyond it).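

In this assay, the exchange of 3,4-dimethoxyphenyl for 3-fluorophenyl on the carbonyl carbon gives a 1.9-fold higher number from compound 2 to compound 3 (0.27 log units; within the scatter), so this pair cannot be separated, even though compound 1, which also carries a fluorophenyl group, stands beyond the scatter from compound 2. Changing 2-fluorophenyl to 3-fluorophenyl gives a 1.3-fold lower number from compound 1 to compound 3 (0.11 log units; within the scatter), so the two fluorophenyl groups cannot be told apart on this read-out, and compound 3 falls within the scatter of both neighbours. Nothing available explains these numbers.

It remains open whether a phenyl group with a single methoxy, a pyridyl group or a 4-fluorophenyl group would separate clearly from the groups shown here. From the compounds shown here alone, it is also open whether the gap between compound 1 and compound 2 would hold with a different amine side of the core.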